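Trimming a Hydroxyl from a Pyrimidine Sulfoxide

This account rests on a few compounds, and the source may have more. Where it says the series, first, only, none or still open, it means among the compounds named here.

Measured compounds:
compound 1 `CC(C)c1nnsc1C[S+]([O-])C(c1ccccc1)c1ccccc1`: 69100 nM
compound 2 `Cc1scc(C[S+]([O-])C(c2ccccc2)c2ccccc2)c1C`: 284000 nM
compound 3 `Cc1cc(O)nc(C[S+]([O-])C(c2ccccc2)c2ccccc2)n1`: 109000 nM

All three share one core and differ only in the aromatic ring on a saturated chain carbon bound to a sulfur. In an assay on HEK293 cells for inhibition of sodium-dependent dopamine transporter (Homo sapiens), read by scintillation counting, with stated times of 5 min and 1 min (a lower number here means a stronger inhibitor, a higher number a weaker inhibitor), compound 3 sits second highest of the three numbers: it is within the scatter of compound 1, as a 1.6-fold higher number from compound 1 to compound 3 (0.20 log units; within the scatter) shows, while compound 2 stands apart with a 2.6-fold lower number from compound 2 to compound 3 (0.42 log units; beyond the scatter). The whole spread across the three rings is modest, as a 4.1-fold higher number from compound 1 to compound 2 (0.61 log units; beyond the scatter) makes clear.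

Compound 4 `Cc1cnc(C[S+]([O-])C(c2ccccc2)c2ccccc2)nc1` is the next step from compound 3: 5-methylpyrimidin-2-yl in place of 4-hydroxy-6-methylpyrimidin-2-yl on a saturated chain carbon bound to a sulfur. Among the compounds with values here, no measured pair removes only a hydroxy group while keeping the rest of the ring, so none of the three steps tests this change directly. Within the data shown here, they show only that exchanging the entire ring moved the number by modest amounts in either direction. Compound 4 is therefore expected to stay close to compound 3, with a 1.1-fold lower number from compound 3 to compound 4 (0.04 log units; within the scatter) the estimated step and no direction favoured beyond the scatter. The estimate for compound 4 is 100000 nM, expected to fall between 30000 nM and 300000 nM.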

Compound 4, half-maximal inhibitory concentration: 156000 nM
The estimate for compound 4 lay 1.6-fold (0.19 log units) below the measured number, within the range that was stated.
By their numbers in this assay, from the lowest: compounds 1, 3, 4 and 2 (each within the scatter of the next, the first and the last beyond it).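

Replacing 4-hydroxy-6-methylpyrimidin-2-yl with 5-methylpyrimidin-2-yl on a saturated chain carbon bound to a sulfur removes the hydrogen-bond donor of the leaving group, yet in this assay the result cannot be told apart from repeat-measurement noise (a 1.4-fold higher number from compound 3 to compound 4 (0.16 log units; within the scatter)), so this exchange of one pyrimidine for another shows no clear effect at this position. Compound 4 also cannot be separated from the dimethylthiophene compound (a 1.8-fold lower number from compound 2 to compound 4 (0.26 log units; within the scatter)), whereas its gap to the thiadiazole compound is real but modest (a 2.3-fold higher number from compound 1 to compound 4 (0.35 log units; beyond the scatter)), which leaves all four rings in a narrow band of weak inhibitors. Nothing available explains any of these steps.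

The hydroxy group cannot be judged alone, since the two ring names also differ in where the methyl group sits, and a ring differing from compound 3 only by loss of the hydroxy group would be needed to isolate it. As far as these compounds go, whether an amine or a carboxylic acid on the pyrimidine ring would move the number beyond the scatter remains open.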